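The source may report more compounds than this note shows. Statements on the series, on what has been measured and on what is new or still open speak of the compounds shown alone.

In a functional assay on the whole organism (Pleural cavity) for inhibition, with Rattus norvegicus as the target, at a dose of 25 mg/kg (a higher number here means more inhibition at the dose given (going by the name of the read-out), a lower number less inhibition), compound 1, `CC1(C)C(=O)N(Cc2ccccc2)c2ncccc21`, gives 12%. Compound 2, `CC(C)N1C(=O)C(C)(C)c2cccnc21`, is the second of the two compounds measured in this assay, and in this assay compound 2 gives 14%. The two numbers lie within the usual scatter of each other, so neither compound can be set above the other on this evidence. Compound 3, `CN1C(=O)C(C)(C)c2cccnc21`, has not yet been measured in this assay. It differs from compound 2 in one place: methyl in place of isopropyl on an amide-type nitrogen in a ring. Within the data shown here, no measured pair shows this change, so its effect is unknown from these data. Given that compound 1 and compound 2 sit so close in this assay, a step no larger than the scatter is expected, with no clear direction, and the estimated step is a number 2 percentage points lower from compound 2 to compound 3 (within the scatter). For compound 3 in this assay the expected value is 12%, estimated to lie between 0% and 28%.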

Compound 3, a percentage reported as inhibition, in the whole organism at one dose (the size of the read-out at that dose, not a potency): 53%
Estimate against measurement, compound 3: 41 percentage points below; the measured number lies above the stated range.
By their numbers in this assay, from the lowest: compounds 1 and 2 (each within the scatter of the next); then compound 3.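

In this assay the group on the amide-type nitrogen in a ring proves to matter: methyl in place of isopropyl gives a number 39 percentage points higher from compound 2 to compound 3 (beyond the scatter) and hydrogen in place of phenyl on the saturated chain carbon bound to that nitrogen gives a number 41 percentage points higher from compound 1 to compound 3 (beyond the scatter) on the shared core. Compound 1 and compound 2 alone gave no sign of this, since their two different groups left them within the scatter of each other; only with methyl at this position does the read-out separate. Nothing measured here accounts for the difference.

From the compounds shown here alone, it remains open whether ethyl, the step between methyl and isopropyl, would keep the gain, or whether the amide hydrogen alone would match methyl. A chain ending in an amine or a carboxylic acid at this nitrogen is likewise untested among the compounds shown.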